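The source may hold more compounds than are shown below. What is called first, only, known or untested is meant among the compounds shown, and "the series" means these compounds.

Working notes on the series. Compound 1 `COc1cc(C(=O)N/N=C/c2ccc(C(F)(F)F)cc2)cc(OC)c1OC` gives 56.3% in a functional assay on BGC-823 cells (Homo sapiens) for antiproliferative activity, read by MTT assay, tested at 5 uM; a lower number here means a weaker effect, a higher number a stronger effect of the compound at the concentration tested. Compound 2 `COc1ccc(OC)c(/C=N/NC(=O)c2cc(OC)c(OC)c(OC)c2)c1` gives 10.1% in this assay. Compound 3 `COc1cc(C(=O)N/N=C/c2ccc(F)cc2)cc(OC)c1OC` gives 61.1% in this assay and stands highest of the three numbers shown; the nearest number is that of compound 1, with a number 4.8 percentage points higher from compound 1 to compound 3 (within the scatter), so the two are not separated, while the number of compound 2 lies far below that of compound 3, beyond the scatter, though compound 2 differs from compound 3 in more than one place and no single step is given for that pair.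

Compound 4 `COc1cc(C(=O)N/N=C/c2cc(Cl)cc(Cl)c2)cc(OC)c1OC` remains to be measured in this assay. Relative to compound 3 the change is 3,5-dichlorophenyl in place of 4-fluorophenyl on a carbon with a double bond to nitrogen. Among the measured compounds shown here, the one step that bears on this, a change of the group on the same ring, is a number 4.8 percentage points higher from compound 1 to compound 3 (within the scatter), within the scatter. For the measured compounds named here, no measured step exchanges fluoro for two chloro groups, and no step tests the 3,5-dichlorophenyl pattern, so the expectation rests on the single small step and carries a wide range. Expected for compound 4 is a step of a number 6.1 percentage points lower from compound 3 to compound 4 (within the scatter) in this assay, none beyond the scatter. Compound 4 is estimated at 55%, between 35% and 75%.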

Compound 4, a percentage reported as inhibition, at one concentration (the size of the read-out at that concentration, not a potency): 9.2%
Compound 4: the middle estimate sits 45.8 percentage points above what was measured; measured number below the stated range.
By their numbers in this assay, from the lowest: compounds 4 and 2 (each within the scatter of the next); then compounds 1 and 3 (each within the scatter of the next).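

In this assay the aryl group on the carbon with a double bond to nitrogen is not a free choice: 3,5-dichlorophenyl in place of 4-fluorophenyl gives a number 51.9 percentage points lower from compound 3 to compound 4 (beyond the scatter), whereas the earlier exchange on the same ring gave only a number 4.8 percentage points higher from compound 1 to compound 3 (within the scatter). Halogen on this ring therefore does not by itself keep the number high, and compound 4 at 9.2% now lies within the scatter of compound 2 at 10.1%, which carries no halogen. No measurement at hand explains the gap between the two groups.

The compounds shown leave open whether the fall belongs to chlorine itself or to the pattern of 3,5-dichlorophenyl: a phenyl with one chlorine and a phenyl with two fluoro groups in that same pattern would separate the two. Also open, as far as these compounds go, is whether an amine or a carboxylic acid on this ring would keep the number of compound 3 at 61.1%.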